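Cyclohexyl on the amide-type nitrogen of compound 2

The source may report more compounds than this note shows. Statements on the series, on what has been measured and on what is new or still open speak of the compounds shown alone.

In a functional assay on SK-OV-3 cells (Homo sapiens) for antiproliferative activity, read by MTT assay (a lower number here means a stronger inhibitor, a higher number a weaker inhibitor), compound 1 `C=CCOC(=O)N1CCCc2cc(S(=O)(=O)N3CC(c4ccccc4)NC3=O)ccc21` gives 2750 nM. Compound 2 `NC(=O)N1CCCc2cc(S(=O)(=O)N3CC(c4ccccc4)NC3=O)ccc21` reads > 20000 nM, which is a limit of the assay and not a number. Within the data shown here, the only measured step is an at least 7.2-fold higher number from compound 1 to compound 2 (0.86 log units; beyond the scatter). Compound 3 `O=C(NC1CCCCC1)N1CCCc2cc(S(=O)(=O)N3CC(c4ccccc4)NC3=O)ccc21` is built on compound 2 by one change: cyclohexyl in place of hydrogen on an amide-type nitrogen. The group on the carbonyl carbon is thus no longer the plain amino of compound 2. With one measured step, the evidence is thin, but that step shows this group can shift the reading. Compound 3 is therefore expected to move back towards compound 1 at 2750 nM, without a firm claim of matching it. The expected step is an at least 4.0-fold lower number from compound 2 to compound 3 (0.60 log units; beyond the scatter), towards a lower number. The estimated value for compound 3 is 5000 nM, with an expected range of 1300 nM to 20000 nM.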

Compound 3, half-maximal inhibitory concentration: 1840 nM
Estimate against measurement, compound 3: 2.7-fold (0.43 log units) above; measured number inside the range.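

In this assay, the amide-type nitrogen of this carbonyl group accepts a large carbon substituent: cyclohexyl in place of hydrogen gives an at least 10-fold lower number from compound 2 to compound 3 (1.03 log units; beyond the scatter). The reading of compound 2 is a limit of the assay and not a number, and the step from it carries that limit: the limit of > 20000 nM in this assay, at which 1 of the 3 values shown sits. Cyclohexylamino in place of allyloxy on the carbonyl carbon gives a 1.5-fold lower number from compound 1 to compound 3 (0.17 log units; within the scatter), so a nitrogen on this carbonyl carbon does not by itself go with the weak reading of compound 2.

Going by these compounds, whether the six-membered ring is needed stays open, as a methyl, a longer chain such as n-butyl or an aromatic phenyl on the same nitrogen could read differently. Also open, on these data alone, is how an amine or a carboxylic acid on the cyclohexyl would read in this assay.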